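A few compounds are considered here, and "the series" means these few. Any claim that something is new, unique, unknown or untested is made for them only; others in the source may bear on it.

Measured in an ADME assay on MT4 cells (Homo sapiens) for cytotoxicity, read by MTT assay, with a stated time of 96 h; a higher number here means that more compound is tolerated, a lower number that less compound is tolerated:
compound 1, `NS(=O)(=O)c1ccc(N2N=C(c3ccc(Oc4ccccc4)cc3)CC2c2ccccc2F)cc1`, 36000 nM
compound 2, `NS(=O)(=O)c1ccc(N2N=C(c3ccc(Oc4ccccc4)cc3)CC2c2ccc(Cl)cc2)cc1`, 9000 nM
compound 3, `NS(=O)(=O)c1ccc(N2N=C(c3ccc(Oc4ccccc4)cc3)CC2c2ccccc2)cc1`, 42000 nM

Compound 3 gives the highest number of the three in this assay. Compound 1 sits closest to it, a 1.2-fold higher number from compound 1 to compound 3 (0.07 log units; within the scatter), a gap within the scatter; compound 2 is furthest, a 4.7-fold higher number from compound 2 to compound 3 (0.67 log units; beyond the scatter), a modest step beyond the scatter.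

Compound 4 is `Cc1ccc(C2CC(c3ccc(Oc4ccccc4)cc3)=NN2c2ccc(S(N)(=O)=O)cc2)cc1`. It differs from compound 3 by methyl in place of hydrogen on an aromatic carbon. The change sits on the phenyl attached to the saturated ring carbon, the same ring on which the three measured compounds differ. Going by the values given here, two measured steps bear on it. Taking fluoro off that ring, a 1.2-fold higher number from compound 1 to compound 3 (0.07 log units; within the scatter), stays within the scatter. Taking chloro off the position para to a large group, a 4.7-fold higher number from compound 2 to compound 3 (0.67 log units; beyond the scatter), is a modest step beyond the scatter, and the reverse step, a 4.0-fold lower number from compound 1 to compound 2 (0.60 log units; beyond the scatter), reads the same way. A methyl entering at that position is therefore expected to lower the number in this assay, though only one substituent has been measured there and methyl is not chloro, so the expected step is set smaller, a 1.9-fold lower number from compound 3 to compound 4 (0.28 log units; within the scatter), at the edge of the scatter. Compound 4 is estimated at 22000 nM, with a range of 9000 nM to 50000 nM.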

Compound 4, half-maximal cytotoxic concentration: 7200 nM
Estimate against measurement, compound 4: 3.1-fold (0.49 log units) above, outside the stated range (below it).
By their numbers in this assay, from the lowest: compounds 4 and 2 (each within the scatter of the next); then compounds 1 and 3 (each within the scatter of the next).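

In this assay, methyl para to a large group gives a 5.8-fold lower number from compound 3 to compound 4 (0.77 log units; beyond the scatter), so the lower number at this place is no longer tied to chloro alone. The two substituents cannot be told apart here, with a 1.3-fold lower number from compound 2 to compound 4 (0.10 log units; within the scatter), and compounds 2 and 4 therefore stand together as the low pair of the series. The change from 2-fluorophenyl to 4-methylphenyl, a 5.0-fold lower number from compound 1 to compound 4 (0.70 log units; beyond the scatter), reads the same way: among the four compounds, the two with a substituent para to a large group carry the lower numbers, and none goes against this, while nothing available accounts for the drop.

Open, from the compounds shown here alone, is whether the lower number follows any group at this place, since only methyl and chloro stand there; 4-fluorophenyl, an amine, a carboxylic acid or a longer chain would test that. Also open is whether methyl elsewhere on the same phenyl would lower the number, since the one substituent shown away from this place is the fluoro of compound 1.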